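The source may report more compounds than this note shows. Statements on the series, on what has been measured and on what is new or still open speak of the compounds shown alone.

This series shares one core and varies the group on the sulfonyl sulfur, with each compound read in an ADME assay on Vero cells (Chlorocebus sabaeus) for cytotoxicity, read by MTT assay; a higher number here means that more compound is tolerated, a lower number that less compound is tolerated. Compound 1 `Cn1nc(C(F)(F)F)cc1C(=O)Nc1ccc(S(=O)(=O)N2CCOCC2)cc1` carries morpholin-4-yl there. The reading for compound 1, > 300000 nM, is a limit of the assay and not a number. Compound 2 `Cn1nc(C(F)(F)F)cc1C(=O)Nc1ccc(S(=O)(=O)N2CCCCC2CO)cc1` carries 2-(hydroxymethyl)piperidin-1-yl and gives a true number, 159000 nM. Compound 3 `Cn1nc(C(F)(F)F)cc1C(=O)Nc1ccc(S(=O)(=O)N2CCCCC2C(=O)O)cc1` carries 2-carboxypiperidin-1-yl. The reading for compound 3, > 300000 nM, is also only a limit.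

Compound 4 `Cn1nc(C(F)(F)F)cc1C(=O)Nc1ccc(S(=O)(=O)N2CCCC(C(=O)O)C2)cc1` keeps the same atoms but joins them differently: 3-carboxypiperidin-1-yl in place of 2-carboxypiperidin-1-yl on a sulfonyl sulfur. In words, this is 3-carboxypiperidin-1-yl in place of 2-carboxypiperidin-1-yl on a sulfonyl sulfur. Among the compounds with values here, no measured step makes this exact swap, so the evidence is indirect. The nearest steps are an at least 1.8-fold higher number from compound 2 to compound 3 (0.27 log units; that floor lies within the scatter), then an at least 1.8-fold lower number from compound 1 to compound 2 (0.27 log units; that floor lies within the scatter), and finally a step that the two limits leave unreadable from compound 1 to compound 3. None of them shows a change beyond the scatter. The wider picture is the limit of > 300000 nM in this assay, at which 2 of the 3 values shown sit. Since compound 3 offers only > 300000 nM as a starting point, no step beyond the scatter is expected in this assay, in either direction. The expected change is a number no higher from compound 3 to compound 4 (the limit leaves the size open). For compound 4 the estimate is 300000 nM, with an expected range from 130000 nM to 600000 nM.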

Compound 4, half-maximal cytotoxic concentration: > 300000 nM
Compound 4 ended at the assay's limit; the forecaster's own chance of this, stated with the estimate: 70%; the middle value lies on the limit itself.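

Moving the carboxy group from 2-carboxypiperidin-1-yl to 3-carboxypiperidin-1-yl leaves the reading in this assay at the assay's limit, so this change shows no measurable loss of tolerance, and the steps to compound 4 from compound 3 and from compound 1 cannot be read, as both ends of each are limits. Within the data shown here, the one readable step is an at least 1.8-fold higher number from compound 2 to compound 4 (0.27 log units; that floor lies within the scatter), so it does not set compound 4 apart from compound 2. What is new is that the carboxy group now reaches the limit from two different ring places, and the readings of this series gather there: the limit of > 300000 nM in this assay, at which 3 of the 4 values shown sit.

Going by these compounds, how far the true tolerated concentrations of compound 1, compound 3 and compound 4 lie beyond the limit remains unknown, so these three cannot be ranked against one another. Also open, on these data alone, is whether a piperidine carrying an amine in place of the carboxylic acid, or a longer chain ending in the carboxylic acid, on the same sulfonyl sulfur would stay at the limit or give a true number.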